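Opening the Cyclic Amide of Compound 1

The source may report more compounds than this note shows. Statements on the series, on what has been measured and on what is new or still open speak of the compounds shown alone.

Going by the values given here, compound 1 `O=C(c1sc(-c2cccc(F)c2)nc1O)N1CCOC1` is the only compound here with a full number: in an assay on HEK293 cells for inhibition of transient receptor potential cation channel subfamily M member 8 (Homo sapiens), read by FLIPR, with stated times of 5 min and 3 min (a lower number here means a stronger inhibitor, a higher number a weaker inhibitor), compound 1 gives 5500 nM. Compound 2 `CCOC(=O)c1cnc(-c2ccccc2)s1` reaches only a limit of this assay, > 100000 nM, which is the limit of > 100000 nM in this assay, at which 1 of the 2 values shown sits. Compound 3 `CCON(C)C(=O)c1sc(-c2cccc(F)c2)nc1O` differs from compound 1 by a group of 5 heavy atoms (3 carbon, 1 nitrogen, 1 oxygen; no ring) in place of a group of 5 heavy atoms (3 carbon, 1 nitrogen, 1 oxygen; one five-membered non-aromatic ring with 2 hetero atoms), on a carbonyl carbon. Among the compounds with values here, no measured pair covers this change, so the expectation rests on compound 1 alone, and the expected step in this assay a 1.5-fold higher number from compound 1 to compound 3 (0.16 log units; within the scatter) is small, not beyond the scatter. Compound 3 is estimated at 8000 nM, with a range from 2500 nM to 30000 nM.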

Compound 3, half-maximal inhibitory concentration: 1680 nM
Estimate against measurement, compound 3: 4.8-fold (0.68 log units) above; the whole stated range lies above it.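

In this assay, opening the ring on the carbonyl carbon to the ethoxy(methyl)amino group gives a 3.3-fold lower number from compound 1 to compound 3 (0.52 log units; beyond the scatter). Going by these compounds alone, this is the first step read at this position, and it shows that the closed ring is not required for activity here. Compound 3 has the same count of heavy atoms and hydrogen-bond acceptors as compound 1, so the difference lies in how those atoms are arranged. From the compounds shown here alone, whether a dimethylamino group or a longer alkoxy chain on the same carbonyl carbon would lower the number further remains open. Nothing measured here accounts for this step.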